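The compounds below may be only part of what the source reports. "The series", "measured", "known", "first", "only" and "open" are said of these compounds alone.

Series notes on the prostaglandin receptor work.

In an assay on membranes from Chem-1 cells for displacement of a labelled ligand from prostaglandin E2 receptor EP3 subtype (Homo sapiens), read by scintillation counting, with a stated time of 2 h (on this read-out lower numbers stand for stronger inhibition and higher numbers for weaker inhibition), compound 1 `CC(C)C(/C=C1\NC(=O)NC1=O)c1ccc(-c2ccc3cccc(F)c3c2)[nH]c1=O` gives 43 nM. In this assay compound 3 `CC(C)/C(=C1/OC(=O)NC1=O)c1ccc(-c2ccc3cccc(F)c3c2)[nH]c1=O` gives 140 nM and compound 2 `CC(C)[C@H](C[C@@H]1OC(=O)NC1=O)c1ccc(-c2ccc3cccc(F)c3c2)[nH]c1=O` gives 8 nM. Compound 1 therefore stands second highest of the three numbers: its gap to compound 3 lies beyond the scatter, compound 3 being the weaker, and its gap to compound 2 also lies beyond the scatter, compound 2 being the stronger.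

Compound 4 `CC(C)C(c1ccc(-c2ccc3cccc(F)c3c2)[nH]c1=O)C1NC(=O)NC1=O` has not been measured. It differs from compound 1 by a group of 7 heavy atoms (3 carbon, 2 nitrogen, 2 oxygen; one five-membered non-aromatic ring with 2 hetero atoms) in place of a group of 8 heavy atoms (4 carbon, 2 nitrogen, 2 oxygen; one five-membered non-aromatic ring with 2 hetero atoms), on a saturated chain carbon bound to an aromatic carbon and a saturated chain carbon. Among the compounds with values here, no measured pair isolates this change. Compound 2, which has no double bond outside its five-membered ring, shows the lowest number of the three, while compound 3 shows the highest, but compound 2 also carries a different ring and a different chain, so the pair is no clean guide. The step from compound 1 to compound 4 is expected to be a 1.7-fold lower number from compound 1 to compound 4 (0.24 log units; within the scatter), small and toward a lower number. Compound 4 is estimated at 25 nM, within a range from 6 nM to 100 nM.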

Compound 4, inhibition constant: 50 nM
For compound 4 the middle estimate is 2.0-fold (0.30 log units) below the measured one, and the stated range covers the measured number.
By their numbers in this assay, from the lowest: compound 2; then compounds 1 and 4 (each within the scatter of the next); then compound 3.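

Replacing the group of 8 heavy atoms on a saturated chain carbon bound to an aromatic carbon and a saturated chain carbon with 2,5-dioxoimidazolidin-4-yl gives, in this assay, a 1.2-fold higher number from compound 1 to compound 4 (0.07 log units; within the scatter). Within the data shown here, this is the first pair that differs in one place, and it shows that the change from 3 to 2 double bonds outside aromatic rings, with the hydrogen-bond donor and acceptor counts unchanged, does not separate the two compounds at this place. No measurement at hand gives a reason for this result.

From the compounds shown here alone, whether a carboxylic acid or a primary amine on the same carbon would keep the number in this range remains open. The separate mirror-image forms of compound 4 also remain unresolved.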